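Urea versus amide on the anilide of the shared core

The compounds below may be only part of what the source reports. "The series", "measured", "known", "first", "only" and "open" are said of these compounds alone.

Compound 1 `COc1cc(-c2nn(-c3cccc(NC(=O)Nc4cc(C(F)(F)F)cc(C(F)(F)F)c4)c3)cc2-c2ccncc2)ccc1Cl` gives in a functional assay on PC-3 cells (Homo sapiens) for inhibition, read by sulforhodamine B assay, with a stated time of 48 h (a higher number here means a weaker inhibitor of growth, a lower number a stronger inhibitor of growth), a value of 2070 nM. Compound 2 `COc1cc(-c2nn(-c3cccc(NC(=O)c4cccc(C(F)(F)F)c4)c3)cc2-c2ccncc2)ccc1Cl` reaches in this assay only a limit, > 50000 nM, not a number. Of the two values shown, compound 2 thus sits at the limit of > 50000 nM in this assay, at which 1 of the 2 values shown sits. Compound 3 `COc1cc(-c2nn(-c3cccc(NC(=O)Nc4ccc(Cl)c(Cl)c4)c3)cc2-c2ccncc2)ccc1Cl` differs from compound 2 by (3,4-dichlorophenyl)amino in place of 3-(trifluoromethyl)phenyl on a carbonyl carbon. Among the compounds with values here, no measured step covers this change. Like compound 3, compound 1 carries a urea, and compound 1 gives 2070 nM. A large step toward stronger inhibition is therefore expected, an at least 16-fold lower number from compound 2 to compound 3 (1.22 log units; beyond the scatter). For compound 3 the estimate is 3000 nM, within 800 nM to 12000 nM.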

Compound 3, concentration for total growth inhibition: 2830 nM
The estimate for compound 3 lay 1.1-fold (0.03 log units) above the measured number, within the range that was stated.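

In this assay the swap on this carbonyl carbon brings an at least 17-fold lower number from compound 2 to compound 3 (1.24 log units; beyond the scatter). Compound 2 stands at a limit, not a number: the limit of > 50000 nM in this assay, at which 1 of the 3 values shown sits. With compound 3 at 2830 nM and compound 1 at 2070 nM, two ureas with different ring substituents now carry measured numbers.

On these data alone, the step changes the amino nitrogen and the ring substituents together, so their separate contributions remain open. A (3-(trifluoromethyl)phenyl)amino group on the same carbonyl carbon, or a (3,4-dichlorophenyl)methyl group there, would separate them.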